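Swapping the aryl group on the two-carbon chain of compound 2

A few compounds are considered here, and "the series" means these few. Any claim that something is new, unique, unknown or untested is made for them only; others in the source may bear on it.

Measured so far:
compound 1, `C#CCNC1CCc2c(SCc3ccc(Cl)cc3Cl)cccc21`: 3760 nM
compound 2, `C#CCNC1CCc2c(SCCc3cccc(Cl)c3)cccc21`: 82400 nM
compound 3, `C#CCNC1CCc2c(SCc3ccc(Br)cc3)cccc21`: 1310 nM

In an assay on isolated protein for inhibition of Amine oxidase [flavin-containing] B (Homo sapiens) (on this read-out higher numbers stand for weaker inhibition and lower numbers for stronger inhibition), compound 2 gives 82400 nM and stands at the highest number of the three, beyond the scatter from both compound 1 and compound 3. Compound 4, `C#CCNC1CCc2c(SCCc3ccc(OC)cc3)cccc21`, has not been measured. It differs from compound 2 in one place: 4-methoxyphenyl in place of 3-chlorophenyl on a saturated chain carbon, two bonds along the chain from a sulfur. Among the compounds with values here, no measured pair shows this exchange, so its effect rests on expectation alone. Because compound 2 already gives 82400 nM, a weak starting point, the step is expected to be small, within or near the scatter, if anything toward a higher number. The estimate for compound 4 is 110000 nM, with a range from 30000 nM to 400000 nM, which means an expected step of a 1.3-fold higher number from compound 2 to compound 4 (0.13 log units; within the scatter).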

Compound 4, half-maximal inhibitory concentration: 62000 nM
The estimate for compound 4 lay 1.8-fold (0.25 log units) above the measured number, and the stated range covers the measured number.
By their numbers in this assay, from the lowest: compound 3; then compound 1; then compounds 4 and 2 (each within the scatter of the next).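

In this assay, within the data shown here, a 1.3-fold lower number from compound 2 to compound 4 (0.12 log units; within the scatter) stays within the scatter, giving the first direct comparison at this position: on a saturated chain carbon, two bonds along the chain from a sulfur, 4-methoxyphenyl and 3-chlorophenyl cannot be told apart. This single exchange changes both the substituent and its place on the ring, so neither change can be read alone. Nothing available explains the result. From the compounds shown here alone, it remains open whether a carboxylic acid or an amine on this ring would move the number beyond the scatter, and whether 4-methoxyphenyl would behave the same way on a shorter chain.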